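Adding a sulfonyl group to the indole-type nitrogen of compound 3

The compounds below may be only part of what the source reports. "The series", "measured", "known", "first", "only" and "open" are said of these compounds alone.

Of the compounds shown here, three sharing one core have been measured in a functional assay on 3T3-L1 cells (Mus musculus) for inhibition, with a stated time of 20 min, tested at 20 uM; a higher number here means more inhibition at the concentration tested (going by the name of the read-out), a lower number less inhibition. Compound 3 `Fc1cccc(CNCc2c[nH]c3ccccc23)c1F` gives -1.7% in this assay. Compound 1 `Cc1ccc(S(=O)(=O)n2cc(CN(Cc3cccc(F)c3F)C(=O)C(F)(F)F)c3ccccc32)cc1` gives -5.5%, and compound 2 `Cc1ccc(S(=O)(=O)N(Cc2cccc(F)c2F)Cc2cn(S(=O)(=O)c3ccc(C)cc3)c3ccccc23)cc1` gives -13.9%. The number for compound 3 is the highest of the three, but its gap to compound 1 is within the scatter, while its gap to compound 2 is beyond it. Among the compounds with values here, the one step between measured compounds, a number 8.4 percentage points lower from compound 1 to compound 2 (within the scatter), concerns the amine nitrogen, not the aromatic one.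

Compound 4 `Cc1ccc(S(=O)(=O)n2cc(CNCc3cccc(F)c3F)c3ccccc32)cc1` is not yet measured. It differs from compound 3 by (4-methylphenyl)sulfonyl in place of hydrogen on an aromatic nitrogen. Within the data shown here, no measured step changes this position alone, so nothing bears directly on it. Compounds 1 and 2 both carry this (4-methylphenyl)sulfonyl group on the aromatic nitrogen and show only small numbers, so for compound 4 a step of a number 3.3 percentage points lower from compound 3 to compound 4 (within the scatter) is expected, none beyond the scatter. Compound 4 is estimated at -5%, between -20% and 10%.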

Compound 4, a percentage reported as inhibition, at one concentration (the size of the read-out at that concentration, not a potency): 46%
Beside the measured number, compound 4's estimate is 51 percentage points below it; measured number outside the range, above it.
By their numbers in this assay, from the lowest: compounds 2, 1 and 3 (each within the scatter of the next, the first and the last beyond it); then compound 4.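

In this assay, within the data shown here, the (4-methylphenyl)sulfonyl group on the aromatic nitrogen proves to matter once the amine nitrogen carries a hydrogen: adding it gives a number 47.7 percentage points higher from compound 3 to compound 4 (beyond the scatter) and brings real inhibition into the series for the first time. The hydrogen on the amine nitrogen matters just as much, with a number 51.5 percentage points higher from compound 1 to compound 4 (beyond the scatter) when it replaces (trifluoromethyl)carbonyl and a number 59.9 percentage points higher from compound 2 to compound 4 (beyond the scatter) when it replaces (4-methylphenyl)sulfonyl. Among these four compounds, only compound 4 has both features, and compound 1 and compound 2 could not reveal this, having the aromatic sulfonyl group but a substituted amine nitrogen.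

As far as these compounds go, it remains open whether an acetyl or a methyl group on the aromatic nitrogen would serve as well, or whether a methyl group on the amine nitrogen would keep the inhibition. Nothing available explains the size of these steps.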